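Extending the Chain of Compound 3

The source may report more compounds than this note shows. Statements on the series, on what has been measured and on what is new or still open speak of the compounds shown alone.

Going by the values given here, in a functional assay on HT-29 cells (Homo sapiens) for inhibition, read by sulforhodamine B assay, with a stated time of 72 h (on this read-out lower numbers stand for stronger inhibition and higher numbers for weaker inhibition), compound 3 (`C#Cc1cccc(Nc2ncnc3cc(OCCCCn4ccnc4[N+](=O)[O-])c(OC)cc23)c1`) gives 590 nM, the lowest of the three numbers so far. Compound 1 (`COc1cc2c(Nc3ccc(F)c(Cl)c3)ncnc2cc1OCCCn1ccnc1[N+](=O)[O-]`) gives 2060 nM and compound 2 (`COc1cc2c(Nc3ccc(F)c(Cl)c3)ncnc2cc1OCCOCCn1ccnc1[N+](=O)[O-]`) gives 5520 nM.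

Compound 4 (`C#Cc1cccc(Nc2ncnc3cc(OCCCCCn4ccnc4[N+](=O)[O-])c(OC)cc23)c1`) keeps the shared core of compound 3 and changes only the chain: (2-nitro-1H-imidazol-1-yl)methyl in place of 2-nitro-1H-imidazol-1-yl on a saturated chain carbon, four bonds along the chain from an oxygen on an aromatic ring. In words, (2-nitro-1H-imidazol-1-yl)methyl takes the place of 2-nitro-1H-imidazol-1-yl on a saturated chain carbon, four bonds along the chain from an oxygen on an aromatic ring.

Among the compounds with values here, only one measured step bears on this change, and only loosely: a 2.7-fold higher number from compound 1 to compound 2 (0.43 log units; beyond the scatter). That step replaces (2-nitro-1H-imidazol-1-yl)methyl with 2-(2-nitro-1H-imidazol-1-yl)ethoxy, so it adds an oxygen as well as length, and it was measured on a different core. Within the data shown here, no measured pair tests the change in compound 4 alone. A smaller shift in the same direction is therefore expected in this assay. The expected step is a 1.4-fold higher number from compound 3 to compound 4 (0.16 log units; within the scatter). Compound 4 is estimated at 850 nM, with an expected range of 330 nM to 2200 nM.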

Compound 4, half-maximal inhibitory concentration: 280 nM
The estimate for compound 4 lay 3.0-fold (0.48 log units) above the measured number; the measured number lies below the stated range.
By their numbers in this assay, from the lowest: compound 4; then compound 3; then compound 1; then compound 2.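

On the core of compound 3, lengthening the chain at this place moves the number down in this assay, giving a 2.1-fold lower number from compound 3 to compound 4 (0.32 log units; beyond the scatter). This is the only step shown in which (2-nitro-1H-imidazol-1-yl)methyl replaces 2-nitro-1H-imidazol-1-yl with nothing else changing, and its direction is opposite to that of a 2.7-fold higher number from compound 1 to compound 2 (0.43 log units; beyond the scatter), which adds an oxygen as well as length on a different core, so that earlier step does not carry over to this change. Nothing available explains the gain in this assay.

The compounds shown leave open whether a still longer chain, such as one ending in 3-(2-nitro-1H-imidazol-1-yl)propyl, would lower the number further on this core. They also leave open whether the same lengthening would act alike on the core of compound 1, and whether an amine could stand in place of the 2-nitro-1H-imidazol-1-yl group at the chain end.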